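The source may hold more compounds than are shown below. What is called first, only, known or untested is meant among the compounds shown, and "the series" means these compounds.

Series notes. Compound 1 `CCOC(=O)c1sc(-c2cccc(NC(=O)c3ccccc3F)c2)nc1Nc1ccc(N2CCN(C)CC2)cc1` carries an ethoxy on a carbonyl carbon; compound 3 `CN1CCN(c2ccc(Nc3nc(-c4cccc(NC(=O)c5ccccc5F)c4)sc3C(N)=O)cc2)CC1` differs from it by amino in place of ethoxy on a carbonyl carbon. In a functional assay on Raji cells (Homo sapiens) for antiproliferative activity, read by CCK-8 assay, with a stated time of 72 h, tested at 40 uM (a lower number here means less inhibition, a higher number more inhibition at the concentration tested (going by the name of the read-out)), compound 1 gives 89.8% and compound 3 gives 97.3%, a step of a number 7.5 percentage points higher from compound 1 to compound 3 (within the scatter). Compound 2 `CCOC(=O)c1sc(-c2cccc(NC(=O)c3ccc(Cl)cc3)c2)nc1Nc1ccc(N2CCN(C)CC2)cc1` arises from compound 1 by 4-chlorophenyl in place of 2-fluorophenyl on a carbonyl carbon, and in this assay compound 2 gives 24.3%, so that a number 65.5 percentage points lower from compound 1 to compound 2 (beyond the scatter). Compound 4 `CN1CCN(c2ccc(Nc3nc(-c4cccc(NC(=O)c5ccc(Cl)cc5)c4)sc3C(N)=O)cc2)CC1` is not yet measured; it arises from compound 3 by 4-chlorophenyl in place of 2-fluorophenyl on a carbonyl carbon, the same change on the same place as from compound 1 to compound 2. On that one earlier step the expectation is a drop of similar size, a number 65.3 percentage points lower from compound 3 to compound 4 (beyond the scatter), because compound 1 to compound 2 showed a number 65.5 percentage points lower from compound 1 to compound 2 (beyond the scatter) while the cores differ only by amino in place of ethoxy on a carbonyl carbon. Compound 4 is therefore estimated at 32%, between 10% and 60%.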

Compound 4, a percentage reported as inhibition, at one concentration (the size of the read-out at that concentration, not a potency): 92.6%
For compound 4 the middle estimate is 60.6 percentage points below the measured one; measured number above the stated range.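

In this assay, the change to 4-chlorophenyl from 2-fluorophenyl does not carry over from the ethoxy core to the amino core, where it gives a number 4.7 percentage points lower from compound 3 to compound 4 (within the scatter), and the two steps disagree: the same change on two cores in this assay, a number 65.5 percentage points lower (beyond the scatter) from compound 1 to compound 2 and a number 4.7 percentage points lower (within the scatter) from compound 3 to compound 4, 60.8 percentage points apart, beyond the scatter of two such steps. Read the other way, amino in place of ethoxy gives a number 68.3 percentage points higher from compound 2 to compound 4 (beyond the scatter) with 4-chlorophenyl on the amide carbonyl, so its outcome also depends on the partner group: the same change on two cores in this assay, a number 7.5 percentage points higher (within the scatter) from compound 1 to compound 3 and a number 68.3 percentage points higher (beyond the scatter) from compound 2 to compound 4, 60.8 percentage points apart, beyond the scatter of two such steps. This rests on one set of four compounds at one concentration, so it shows that the two changes are not independent here, but not why, and it gives no potency order for compound 3 and compound 4.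

Open, going by these compounds, is whether an unsubstituted phenyl on the amide carbonyl follows 2-fluorophenyl or 4-chlorophenyl on each core. Also open, on these data alone, is whether methylamino on the other carbonyl carbon behaves like amino or like ethoxy.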